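Compound 3: 3-chlorophenyl in place of pyridin-3-yl

The compounds below may be only part of what the source reports. "The series", "measured", "known", "first", "only" and "open" are said of these compounds alone.

Within the data shown here, in an ADME assay for permeability, using PAMPA, at pH 7.4 (on this read-out higher numbers stand for higher permeability and lower numbers for lower permeability), compound 2 (`Cc1cc(NC(=O)Nc2cccnc2)c2ccccc2n1`) gives 63 10^-6 cm/s as the lower of the two numbers so far, and compound 1 (`Cc1ccc(NC(=O)Nc2cc(C)nc3ccccc23)cc1`) gives 669 10^-6 cm/s as the higher. Next is compound 3 (`Cc1cc(NC(=O)Nc2cccc(Cl)c2)c2ccccc2n1`) with 3-chlorophenyl in place of pyridin-3-yl on an amide-type nitrogen whose other neighbour is the carbonyl carbon, and 3-chlorophenyl in place of pyridin-3-yl on an amide-type nitrogen gives the counted change. Among the measured compounds shown here, only one measured step bears on this: an 11-fold lower number from compound 1 to compound 2 (1.03 log units; beyond the scatter) with pyridin-3-yl in place of 4-methylphenyl at that place, and it is large and beyond the scatter. For the measured compounds named here, compound 1 at 669 10^-6 cm/s is the only measured compound with a ring of carbon only there, and compound 3 also has such a ring, so a rise towards that number is expected. One step is thin support, and 3-chlorophenyl has not yet been compared with 4-methylphenyl. The expected step is a 7.9-fold higher number from compound 2 to compound 3 (0.90 log units; beyond the scatter) in this assay and is upward and beyond the scatter. For compound 3 the estimate is 500 10^-6 cm/s with an expected range from 200 10^-6 cm/s to 1100 10^-6 cm/s in this read-out.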

Compound 3, apparent permeability: 566 10^-6 cm/s
Beside the measured number, compound 3's estimate is 1.1-fold (0.05 log units) below it; measured number inside the range.
By their numbers in this assay, from the lowest: compound 2; then compounds 3 and 1 (each within the scatter of the next).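

In this assay, among these compounds, 3-chlorophenyl in place of pyridin-3-yl on an amide-type nitrogen gives a 9.0-fold higher number from compound 2 to compound 3 (0.95 log units; beyond the scatter) and so shows that the low number of compound 2 is not simply recovered by 4-methylphenyl alone: a second ring of carbon only, with a different substituent, also gives a high number. 3-chlorophenyl in place of 4-methylphenyl at this nitrogen gives a 1.2-fold lower number from compound 1 to compound 3 (0.07 log units; within the scatter), so across the three compounds the clear divide lies between the pyridin-3-yl ring and the two rings of carbon only, with no compound against it and no separation between chlorine and methyl in this read-out. No measured property of these groups accompanies the numbers, and the divide therefore stands as an observation without an explanation.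

As far as these compounds go, whether the low number goes with pyridin-3-yl in particular or with hetero-atom rings more widely remains open, and pyridin-4-yl, pyrimidinyl, unsubstituted phenyl or a phenyl ring carrying an amine or a carboxylic acid at this nitrogen would bear on that. From the compounds shown here alone, only the group on this nitrogen varies here, so whether these steps hold on a changed core also remains open.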